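Cytotoxicity notes: phenoxy replacing 2-oxopyrrolidin-1-yl in compound 4

A few compounds are considered here, and "the series" means these few. Any claim that something is new, unique, unknown or untested is made for them only; others in the source may bear on it.

Compound 1 `O=C(Nc1cccc(N2CCCC2=O)c1)C1CCCN(C(=O)c2cc(C(F)(F)F)cc(C(F)(F)F)c2)C1`, compound 2 `COC(=O)c1cccc(C(=O)N2CCCC(C(=O)Nc3ccc(Cl)cc3)C2)c1` and compound 3 `CC(=O)Nc1cccc(C(=O)N2CCCC(C(=O)Nc3ccc(Cl)cc3)C2)c1` have been measured in an ADME assay on PC-3 cells (Homo sapiens) for cytotoxicity, read by WST assay, tested at 100 uM; a lower number here means less inhibition, a higher number more inhibition at the concentration tested (going by the name of the read-out). Compound 1 gives 0%, compound 2 gives 0% and compound 3 gives 4%; compound 1 stands level with compound 2 at the digits shown, and all three numbers lie within the scatter of one another. Going by the values given here, the single measured step, a number 4 percentage points higher from compound 2 to compound 3 (within the scatter), is within the scatter. Compound 4 `O=C(Nc1cccc(Oc2ccccc2)c1)C1CCCN(C(=O)c2cc(C(F)(F)F)cc(C(F)(F)F)c2)C1` differs from compound 1 by phenoxy in place of 2-oxopyrrolidin-1-yl on an aromatic carbon. Among the compounds with values here, no measured step touches that part of the molecule, so nothing in the data speaks for a step in this assay beyond the scatter. Compound 4 is therefore expected to show no change at the digits printed from compound 1 to compound 4 (within the scatter), no change beyond the scatter. The estimate for compound 4 is 0% with a range of -5% to 10%.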

Compound 4, a percentage reported as inhibition, at one concentration (the size of the read-out at that concentration, not a potency): 1%
Compound 4: the middle estimate sits 1 percentage points below what was measured, and the stated range covers the measured number.
By their numbers in this assay, from the lowest: compounds 1, 2, 4 and 3 (each within the scatter of the next).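

Going by these compounds alone, with a number 1 percentage points higher from compound 1 to compound 4 (within the scatter) in this assay, phenoxy in place of 2-oxopyrrolidin-1-yl is the only step read at this position, on an aromatic carbon meta to a large group. Exchanging a five-membered non-aromatic ring for a six-membered aromatic ring of carbon only therefore stays within the scatter here. Nothing available accounts for this result. On these data alone, whether an amine or a carboxylic acid at this position would give a step beyond the scatter in this assay remains open.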